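Oxygen to sulfur in the aryl linker: compound 4 expected

A few compounds are considered here, and "the series" means these few. Any claim that something is new, unique, unknown or untested is made for them only; others in the source may bear on it.

Measured compounds in a functional assay on U-251 cells (Homo sapiens) for inhibition, read by sulforhodamine B assay, with a stated time of 48 h; a higher number here means a weaker inhibitor of growth, a lower number a stronger inhibitor of growth:
Compound 1 `Nc1cc(N)c2nc(-c3ccccc3)c(NCc3ccc(F)cc3)nc2c1`: 3160 nM
Compound 2 `COc1ccc(Sc2nc3cc(N)cc(N)c3nc2-c2ccccc2)cc1`: < 100000 nM, a limit of this assay, not a number
Compound 3 `Nc1cc(N)c2nc(-c3ccccc3)c(Oc3ccc(F)cc3)nc2c1`: 79400 nM

Compound 3 carries the highest of the two readable numbers; its nearest neighbour is compound 1, with the step of a 25-fold higher number from compound 1 to compound 3 (1.40 log units; beyond the scatter). Among the measured compounds shown here, the only other value, that of compound 2, is a limit (the limit of < 100000 nM in this assay, at which 1 of the 3 values shown sits), so the step that the limit leaves unreadable from compound 2 to compound 3 cannot be sized.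

Compound 4 `Nc1cc(N)c2nc(-c3ccccc3)c(Sc3ccc(F)cc3)nc2c1` has not yet been measured. It differs from compound 3 in one place: (4-fluorophenyl)sulfanyl in place of 4-fluorophenoxy on an aromatic carbon. For the measured compounds named here, no measured step follows this exact oxygen-to-sulfur swap. The one sulfur-linked compound shown, compound 2, sits at a limit, so it gives no number to lean on. The step from compound 3 to compound 4 is therefore expected to be modest, most likely a somewhat lower number that stays within the scatter. The estimated step is a 1.6-fold lower number from compound 3 to compound 4 (0.20 log units; within the scatter). Compound 4 is estimated at 50000 nM, within 12000 nM to 200000 nM.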

Compound 4, concentration for total growth inhibition: 31600 nM
Compound 4: the middle estimate sits 1.6-fold (0.20 log units) above what was measured; the measured number falls inside the stated range.
By their numbers in this assay, from the lowest: compound 1; then compound 4; then compound 3.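

In this assay the atom linking the 4-fluorophenyl ring to the core matters at this position: sulfur in place of oxygen gives a 2.5-fold lower number from compound 3 to compound 4 (0.40 log units; beyond the scatter) with the same count of heavy atoms. The (4-fluorobenzyl)amino group of compound 1 still stands apart, with a 10-fold higher number from compound 1 to compound 4 (1.00 log units; beyond the scatter) marking a larger gap than the oxygen-to-sulfur swap covers. Steps involving compound 2 cannot be read because its value is a limit, not a number: the limit of < 100000 nM in this assay, at which 1 of the 4 values shown sits.

As far as these compounds go, it remains open whether the lower number of compound 1 comes from its nitrogen link or from the benzyl spacer, and whether the sulfur effect holds with other groups on the aryl ring. A phenylamino, benzyloxy or benzylsulfanyl group at this position would separate the link from the spacer.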